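Changing one ring on compound 2 before it is measured

The compounds below may be only part of what the source reports. "The series", "measured", "known", "first", "only" and "open" are said of these compounds alone.

Of the compounds shown here, three have been tested in a functional assay on Huh-7 cells (Homo sapiens), read by fluorescence and BrdU incorporation, with a stated time of 48 h, tested at 10 uM (a lower number here means a stronger effect, a higher number a weaker effect of the compound at the concentration tested), and a fourth awaits its turn. Compound 1 `COc1cc(O)c(C(=O)/C=C/c2ccc(F)cc2)c(OC)c1` gives "not active" (no number reported) there, a result that comes without a number. Compound 2 `COc1cc(OC)c(C(=O)/C=C/c2ccc(Cl)cc2)c(OC)c1` gives 33%, and compound 3 `COc1cccc(/C=C/C(=O)c2c(O)cc(OC)cc2OC)c1` gives 56%. Of the two compounds with a number, compound 2 has the lower one and therefore the stronger effect, and its gap to compound 3 lies beyond the usual scatter of repeated measurements.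

Compound 4 `COc1cc(OC)c(C(=O)/C=C/c2ccccc2SC)c(OC)c1` has not yet been measured. It differs from compound 2 in a single place: 2-(methylsulfanyl)phenyl in place of 4-chlorophenyl on a double-bonded chain carbon bound to a double-bonded chain carbon. The 4-chlorophenyl group is gone, and the entering 2-(methylsulfanyl)phenyl group brings one hydrogen-bond acceptor that the leaving group lacked.

Going by the values given here, no measured pair in this set differs in only one place, so the data give no direct guide to what such a swap does in this assay. The expected outcome is a modest step toward a weaker effect, one that may still fall within the scatter, so that a number 12 percentage points higher from compound 2 to compound 4 (beyond the scatter) is the estimated step. Compound 4 is thus estimated at 45%, with a range from 25% to 70%.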

Compound 4, a percentage reported as activity, at one concentration (the size of the read-out at that concentration, not a potency): 37%
Beside the measured number, compound 4's estimate is 8 percentage points above it, and the stated range covers the measured number.
By their numbers in this assay, from the lowest: compounds 2 and 4 (each within the scatter of the next); then compound 3.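

Going by these compounds alone, this is the first pair in the set that differs in only one place, and in this assay it gives a number 4 percentage points higher from compound 2 to compound 4 (within the scatter). On a double-bonded chain carbon bound to a double-bonded chain carbon, then, 2-(methylsulfanyl)phenyl can take the place of 4-chlorophenyl and the two readings stay within the scatter of each other, even with the hydrogen-bond acceptor that the entering group brings. No measurement at hand explains this result.

Still open, from the compounds shown here alone, is how this place would respond to a quite different group, such as an amine or a carboxylic acid on the ring, or a longer chain in place of the methyl on sulfur. Also open, going by these compounds, is whether the same swap would read alike on the core of compound 3.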